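The source may report more compounds than this note shows. Statements on the series, on what has been measured and on what is new or still open speak of the compounds shown alone.

Measured so far in a functional assay for antagonist activity at Oxoeicosanoid receptor 1 (Homo sapiens), read by fluorescence and calcium flux, with stated times of 2 min and 1 min; a higher number here means a weaker inhibitor, a lower number a stronger inhibitor:
compound 1, `C[C@H](CC(=O)O)CC(=O)c1c(CCCCCCc2ccccc2)n(C)c2ccc(Cl)cc12`, gives 0.12 nM.
compound 2, `C[C@H](CC(=O)O)CC(=O)c1c([C@H](O)CCCCCc2ccccc2)n(C)c2ccc(Cl)cc12`, gives 260 nM.
compound 3, `C[C@@H](CC(=O)O)CC(=O)c1c([C@@H](O)CCCCCc2ccccc2)n(C)c2ccc(Cl)cc12`, gives 120 nM.

Compound 3 stands second highest of these three numbers in this assay: its nearest neighbour is compound 2, while compound 1 lies far below it. Two steps have been measured. The large step of a 2200-fold higher number from compound 1 to compound 2 (3.34 log units; beyond the scatter) came from placing a hydroxy on a saturated chain carbon bound to an aromatic carbon and a saturated chain carbon. The step of a 2.2-fold lower number from compound 2 to compound 3 (0.34 log units; beyond the scatter) is modest, and because the fact that compounds 2 and 3 differ only in the configuration as drawn it shows how much the mirror-image arrangement alone can shift the number.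

Compound 4, `C[C@@H](CC(=O)O)CC(=O)c1c(CCCCCCc2ccccc2)n(C)c2ccc(Cl)cc12`, is not yet measured. hydrogen in place of hydroxy on a saturated chain carbon bound to an aromatic carbon and a saturated chain carbon This is the reverse of the change that produced the large step of a 2200-fold higher number from compound 1 to compound 2 (3.34 log units; beyond the scatter), so a large fall in the number in this assay is expected, with the modest size of a 2.2-fold lower number from compound 2 to compound 3 (0.34 log units; beyond the scatter) as a guide to how much the configuration alone may move it. Compound 4 is therefore estimated at 0.1 nM, within 0.03 nM to 0.6 nM, which means an expected step of a 1200-fold lower number from compound 3 to compound 4 (3.08 log units; beyond the scatter).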

Compound 4, half-maximal inhibitory concentration: 23 nM
The estimate for compound 4 lay 230-fold (2.36 log units) below the measured number; measured number outside the range, above it.
By their numbers in this assay, from the lowest: compound 1; then compound 4; then compound 3; then compound 2.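

In this assay, swapping the hydroxy for hydrogen on the saturated chain carbon bound to an aromatic carbon and a saturated chain carbon gives a 5.2-fold lower number from compound 3 to compound 4 (0.72 log units; beyond the scatter), so the size of this change depends on the configuration of the compound that carries it: the same change on two cores in this assay, a 2200-fold higher number (3.34 log units; beyond the scatter) from compound 1 to compound 2 and a 5.2-fold higher number (0.72 log units; beyond the scatter) from compound 4 to compound 3, 420-fold (2.62 log units) apart, beyond the scatter of two such steps. The remaining stereocentre also matters far more without the hydroxy than the mirror-image pair suggested, for inverting it alone gives a 190-fold higher number from compound 1 to compound 4 (2.28 log units; beyond the scatter), while inverting both stereocentres in the hydroxy compounds gave only a 2.2-fold lower number from compound 2 to compound 3 (0.34 log units; beyond the scatter): the fact that compounds 1 and 4 differ only in the configuration as drawn. Of the four compounds, only compound 1, at 0.12 nM, combines the chain without hydroxy with the configuration that gives the lowest number, and neither change alone tells the whole story.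

Compounds 2 and 3 invert both stereocentres together, which leaves open how each stereocentre acts on its own when the hydroxy is present. Also open, on these data alone, is how the number would respond to a methoxy group or a fluorine atom on that same chain carbon.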